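The source may hold more compounds than are shown below. What is called first, only, known or untested is meant among the compounds shown, and "the series" means these compounds.

Compound 1 `COC(=O)CC[C@@H]1NC(=O)[C@@H](C)NC(=O)[C@@H]2Cc3ccc(OC)c(c3)Oc3ccc(cc3)C[C@@H](C(=O)N2C)N(C)C(=O)[C@H](C)NC(=O)[C@H](Cc2ccc(OC)cc2)N(C)C1=O`: 58.9 nM
Compound 2 `COC(=O)C[C@@H]1NC(=O)[C@@H](C)NC(=O)[C@@H]2Cc3ccc(OC)c(c3)Oc3ccc(cc3)C[C@@H](C(=O)N2C)N(C)C(=O)[C@H](C)NC(=O)[C@H](Cc2ccc(OC)cc2)N(C)C1=O`: 41.7 nM

In a functional assay on P388 cells (Mus musculus) for cytotoxicity (a lower number here means a stronger inhibitor, a higher number a weaker inhibitor), compound 2 sits within the scatter of compound 1, so neither stands apart on the two numbers shown. Compound 3 `COc1ccc(C[C@H]2C(=O)N[C@@H](C)C(=O)N(C)[C@H]3Cc4ccc(cc4)Oc4cc(ccc4OC)C[C@@H](C(=O)N[C@H](C)C(=O)N[C@@H](CO)C(=O)N2C)N(C)C3=O)cc1` carries the change (hydroxy in place of methoxycarbonyl on a saturated chain carbon bound to a saturated ring carbon). Among the compounds with values here, the one measured step, a 1.4-fold lower number from compound 1 to compound 2 (0.15 log units; within the scatter), shortened the same side chain without a shift beyond the scatter, but no measured step exchanges the ester for a hydroxy, so it bears only loosely here. The expectation is a step of a 1.4-fold higher number from compound 2 to compound 3 (0.16 log units; within the scatter), not beyond the scatter. Compound 3 is therefore estimated at 60 nM, between 20 nM and 200 nM.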

Compound 3, half-maximal inhibitory concentration: 14.1 nM
Compound 3: middle estimate off by 4.3-fold (0.63 log units), on the high side, outside the stated range (below it).
By their numbers in this assay, from the lowest: compound 3; then compounds 2 and 1 (each within the scatter of the next).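

In this assay the side chain on a saturated chain carbon bound to a saturated ring carbon does matter: hydroxy in place of methoxycarbonyl gives a 3.0-fold lower number from compound 2 to compound 3 (0.47 log units; beyond the scatter) and hydroxy in place of (methoxycarbonyl)methyl gives a 4.2-fold lower number from compound 1 to compound 3 (0.62 log units; beyond the scatter) in the same direction. Changing the chain length with the ester kept had stayed within the scatter, so the first shift beyond it comes with the loss of the ester. No accompanying measurement accounts for this shift.

Going by these compounds, whether the hydroxy itself matters, or only the absence of the ester, remains open. A carboxylic acid, an amine or a longer chain ending in hydroxy at this place could help separate the two.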